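Cyclobutyl to 4-Fluorophenyl: Predicting the Next Agonist

The compounds below may be only part of what the source reports. "The series", "measured", "known", "first", "only" and "open" are said of these compounds alone.

Three compounds of the shared core have been measured in an in vitro functional assay on cells for agonist activity at Bombesin receptor subtype-3 (Homo sapiens), read by luminescence and calcium flux; a lower number here means that less compound is needed, a higher number that more compound is needed for the effect:
compound 1, `O=C(O)c1ccccc1-c1ccc(CCc2ncc(Cc3cccc(Cl)c3)[nH]2)cc1`, gives 825 nM;
compound 2, `O=C(O)c1ccccc1-c1ccc(CCc2ncc(CC3CCC3)[nH]2)cc1`, gives 588 nM;
compound 3, `O=C(O)c1ccccc1-c1ccc(CCc2ncc(Cc3cccc(F)c3F)[nH]2)cc1`, gives 87 nM.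

Compound 2 stands second highest of these three numbers. Its nearest neighbour is compound 1, with a 1.4-fold lower number from compound 1 to compound 2 (0.15 log units; within the scatter), a step within the scatter; its furthest is compound 3, with a 6.8-fold lower number from compound 2 to compound 3 (0.83 log units; beyond the scatter), a step beyond the scatter.

The next compound, compound 4, `O=C(O)c1ccccc1-c1ccc(CCc2ncc(Cc3ccc(F)cc3)[nH]2)cc1`, is not yet measured. It differs from compound 2 in one place: 4-fluorophenyl in place of cyclobutyl on a saturated chain carbon bound to an aromatic carbon.

Going by the values given here, two measured steps bear on this change. Both replace the group on the saturated chain carbon bound to an aromatic carbon with an aryl ring. From compound 2, putting 3-chlorophenyl in place of cyclobutyl amounts to a 1.4-fold lower number from compound 1 to compound 2 (0.15 log units; within the scatter) read backwards, within the scatter, while a 6.8-fold lower number from compound 2 to compound 3 (0.83 log units; beyond the scatter) lowered the number modestly. A single-fluorine aryl ring is therefore expected to sit between these outcomes, giving a small lowering in this assay.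

For compound 4, the expected step is a 2.0-fold lower number from compound 2 to compound 4 (0.29 log units; within the scatter). The estimate for compound 4 is 300 nM, with a range from 100 nM to 900 nM.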

Compound 4, half-maximal effective concentration: 1600 nM
The estimate for compound 4 lay 5.3-fold (0.73 log units) below the measured number; the whole stated range lies below it.
By their numbers in this assay, from the lowest: compound 3; then compounds 2, 1 and 4 (each within the scatter of the next, the first and the last beyond it).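

In this assay, swapping cyclobutyl for 4-fluorophenyl gives a 2.7-fold higher number from compound 2 to compound 4 (0.43 log units; beyond the scatter), so on the saturated chain carbon bound to an aromatic carbon, an aromatic ring carrying fluorine does not lower the number by itself. Going from the 2,3-difluorophenyl ring to the 4-fluorophenyl ring gives an 18-fold higher number from compound 3 to compound 4 (1.26 log units; beyond the scatter), the largest step among these four compounds, which shows that the substituents on the ring matter far more here than the mere presence of an aromatic ring. The 3-chlorophenyl and 4-fluorophenyl rings differ by a 1.9-fold higher number from compound 1 to compound 4 (0.29 log units; within the scatter), so these two rings with a single substituent cannot be told apart, and among the aryl groups shown only the 2,3-difluorophenyl ring of compound 3 gives a clear gain.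

Nothing available here explains why these rings behave so differently. Still open, on these data alone, is how a plain phenyl ring with no halogen would compare, which would show whether the halogens on the ring help at all or whether the gain belongs to the 2,3-difluorophenyl ring alone.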